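This account rests on a few compounds, and the source may have more. Where it says the series, first, only, none or still open, it means among the compounds named here.

Measured compounds:
Compound 1 `COc1cc(C(=O)NC2CCN(C)CC2)ccc1Nc1ncc(Br)c(NC2CCCC2)n1`: 12000 nM
Compound 2 `COc1cc(C(=O)NC2CCN(C)CC2)ccc1Nc1ncc(Cl)c(NC2CCCC2)n1`: 4400 nM

In a functional assay on HCT-8 cells (Homo sapiens) for cytotoxicity, read by MTT assay, with a stated time of 48 h (on this read-out higher numbers stand for weaker inhibition and lower numbers for stronger inhibition), compound 1 gives the highest number of the two measured, so it is the weaker of the pair. For the measured compounds named here, its only neighbour is compound 2, and the step of a 2.7-fold lower number from compound 1 to compound 2 (0.44 log units; beyond the scatter) comes with chloro in place of bromo on an aromatic carbon.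

Compound 3 `CN1CCC(NC(=O)c2ccc(Nc3ncc(Br)c(NC4CCCC4)n3)cc2)CC1` is the next compound to be measured. It differs from compound 1 by hydrogen in place of methoxy on an aromatic carbon. Going by the values given here, this is a change at a different part of the molecule from the one measured step, which touched only the halogen on the shared core, so that step says nothing direct about removing the methoxy group. Among the compounds with values here, with no measured step bearing on this change, the plain expectation is that compound 3 stays close to compound 1, with no step beyond the scatter, though the uncertainty is wide.

On that basis compound 3 is estimated to give 15000 nM in this assay, within a range from 5000 nM to 45000 nM, which corresponds to an expected step of a 1.3-fold higher number from compound 1 to compound 3 (0.10 log units; within the scatter).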

Compound 3, half-maximal inhibitory concentration: 3600 nM
Compound 3: the middle estimate sits 4.2-fold (0.62 log units) above what was measured, outside the stated range (below it).
By their numbers in this assay, from the lowest: compounds 3 and 2 (each within the scatter of the next); then compound 1.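

In this assay, the methoxy group on this aromatic carbon, ortho to a large group and meta to a (1-methylpiperidin-4-yl)carbamoyl group, proves not to be needed for the effect, since replacing it with hydrogen gives a 3.3-fold lower number from compound 1 to compound 3 (0.52 log units; beyond the scatter). For the compounds shown here, until now the only measured change was at the halogen on the shared core, so this is the first sign that the read-out also responds at this second place, and here the loss of two heavy atoms (1 carbon, 1 oxygen) goes with stronger inhibition, not weaker. Nothing measured here accounts for the direction of this step.

The compounds shown leave open whether another group on this carbon, such as ethoxy, a fluorine atom or an amine, would give a lower or a higher number than methoxy or hydrogen. They also leave open whether the step seen on removing methoxy would hold with chloro in place of bromo on the shared core.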